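A new side arm for compound 3

A few compounds are considered here, and "the series" means these few. Any claim that something is new, unique, unknown or untested is made for them only; others in the source may bear on it.

Three compounds share one core and the same amide-linked acid: compound 1 `Cc1c(C(=O)N[C@@H](C)c2ccc(C(=O)O)cc2)nnn1Cc1ccc(C(F)(F)F)cc1`, compound 2 `CCc1c(C(=O)N[C@@H](C)c2ccc(C(=O)O)cc2)nnn1Cc1ccc(C(F)(F)F)cc1` and compound 3 `C[C@H](NC(=O)c1c(C(F)(F)F)nnn1Cc1ccc(C(F)(F)F)cc1)c1ccc(C(=O)O)cc1` differ only in the small group on that core. In a functional assay on CHO cells for antagonist activity at prostaglandin E2 receptor EP4 subtype (Homo sapiens), read by calcium flux, with a stated time of 15 min (a higher number here means a weaker inhibitor, a lower number a stronger inhibitor), compound 1 gives > 10000 nM, which is a limit of the assay and not a number. In this assay compound 2 likewise gives only a limit, > 10000 nM. The step that the two limits leave unreadable from compound 1 to compound 2 is therefore not readable. Among the measured compounds shown here, compound 3 gives 225 nM in this assay, the only number among the three, the other two values sitting at the limit of > 10000 nM in this assay, at which 2 of the 3 values shown sit.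

Compound 4 `C[C@H](NC(=O)c1c(C(F)(F)F)nnn1CCOc1ccc(F)cc1)c1ccc(C(=O)O)cc1` has not yet been measured. It differs from compound 3 by (4-fluorophenoxy)methyl in place of 4-(trifluoromethyl)phenyl on a saturated chain carbon bound to an aromatic nitrogen, while the trifluoromethyl group on the core stays as in compound 3. For the measured compounds named here, no measured step concerns this part of the molecule: the one measured step, from compound 1 to compound 2, lies elsewhere and its size is hidden by the two limits. Going by the values given here, nothing among the measured compounds points to a direction. The step of a 1.3-fold higher number from compound 3 to compound 4 (0.12 log units; within the scatter) is therefore estimated as none beyond the scatter. Among the compounds with values here, compound 4 is thus expected to give about 300 nM in this assay, within a range from 60 nM to 1500 nM; the range is wide, as no measured step bears on this change.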

Compound 4, half-maximal inhibitory concentration: 276 nM
Compound 4: middle estimate off by 1.1-fold (0.04 log units), on the high side; the range from low to high includes it.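

In this assay the exchange of the side arm gives a 1.2-fold higher number from compound 3 to compound 4 (0.09 log units; within the scatter) and so leaves 4-(trifluoromethyl)benzyl and 2-(4-fluorophenoxy)ethyl indistinguishable in this read-out. This is the first readable step among the compounds shown, and it falls on a saturated chain carbon bound to an aromatic nitrogen, a part of the molecule that did not vary among the earlier compounds. The side arm can therefore lose its trifluoromethyl group and take up an oxygen, with its hydrogen-bond acceptor, without a shift beyond the scatter, but nothing shown accounts for why the two side arms read alike.

From the compounds shown here alone, it remains open whether this holds for other side arms, such as a longer chain, an amine in place of the oxygen or a nitrile in place of the fluorine. Going by these compounds, it is equally open whether the two side arms would still read alike with another small group on the core, such as chlorine or cyclopropyl, in place of the trifluoromethyl group.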